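Changing the Group on the Carbonyl Carbon of Compound 3

The source may hold more compounds than are shown below. What is called first, only, known or untested is meant among the compounds shown, and "the series" means these compounds.

The measured compounds and their values in an assay on membranes from HeLa cells for displacement of a labelled ligand from adenosine receptor A3 (Homo sapiens), read by scintillation counting, with a stated time of 180 min, tested at 1 uM; on this read-out higher numbers stand for more inhibition at the one concentration tested (going by the name of the read-out) and lower numbers for less inhibition:
compound 1, `CCNC(=O)C1=C(C)NC(=O)NC1c1cccs1`, gives 4%;
compound 2, `CC1=C(C(=O)NC(C)C)C(c2cccs2)NC(=O)N1`, gives 1%;
compound 3, `CC1=C(C(=O)SC(C)C)C(c2cccs2)NC(=O)N1`, gives 1%.

Compound 3 stands level with compound 2, the two together the lowest of the three, with compound 1 only slightly higher and within the scatter. Compound 4, `CC1=C(C(=O)OC2CCCC2)C(c2cccs2)NC(=O)N1`, differs from compound 3 in one place: cyclopentyloxy in place of isopropylsulfanyl on a carbonyl carbon. Among the compounds with values here, two measured steps touch the same carbonyl carbon: a number 3 percentage points lower from compound 1 to compound 3 (within the scatter) and no change at the digits printed from compound 2 to compound 3 (within the scatter). Neither exchange on that carbon moved the number beyond the scatter, so no step beyond the scatter is expected here either, giving an estimated a number 2 percentage points higher from compound 3 to compound 4 (within the scatter). Compound 4 is therefore expected to show 3%, between -6% and 14%.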

Compound 4, a percentage reported as inhibition, at one concentration (the size of the read-out at that concentration, not a potency): 1%
The estimate for compound 4 lay 2 percentage points above the measured number; the measured number falls inside the stated range.
By their numbers in this assay, from the lowest: compounds 2, 3, 4 and 1 (each within the scatter of the next).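

With cyclopentyloxy, this carbonyl carbon now carries a five-membered ring and an oxygen link, yet this assay shows no change at the digits printed from compound 3 to compound 4 (within the scatter). Set against the nitrogen-linked groups, the same group gives no change at the digits printed from compound 2 to compound 4 (within the scatter) and a number 3 percentage points lower from compound 1 to compound 4 (within the scatter), so none of the four groups on this carbon stands apart beyond the scatter. No supporting evidence bears on this flat result. Going by these compounds, whether a carboxylic acid or a benzylamino group on this carbon would raise the number remains open. So does whether a group other than those on the shared core would.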